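A few compounds are considered here, and "the series" means these few. Any claim that something is new, unique, unknown or untested is made for them only; others in the source may bear on it.

Compound 2 `CC1=C(CC/C(C)=C/CC/C(C=O)=C\C=C\C2=CC(=O)O[C@H]2O)C(C)(C)CCC1` gives 0.45 ug/mL in a functional assay on L1210 cells (Mus musculus) for cytotoxicity (on this read-out lower numbers stand for stronger inhibition and higher numbers for weaker inhibition), the lowest of the two numbers in hand; compound 1 `CC1=C(CCC(C)(O)/C=C/C/C(=C/CC2OC(=O)C=C2CO)CO)C(C)(C)CCC1` gives 2.8 ug/mL in this assay, a gap beyond the scatter. Compound 3 `CC1=C(CC/C(C)=C/CC/C(C=O)=C\C[C@H]2OC(=O)C=C2CO)C(C)(C)CCC1` awaits measurement. It differs from compound 2 by a group of 9 heavy atoms (6 carbon, 3 oxygen; one five-membered non-aromatic ring with 1 hetero atom) in place of a group of 9 heavy atoms (6 carbon, 3 oxygen; one five-membered non-aromatic ring with 1 hetero atom), on a double-bonded chain carbon bound to a double-bonded chain carbon. Among the measured compounds shown here, no pair of measured compounds isolates this change; compound 1 also differs from compound 2 at other places, so its number is no clean guide. A moderate loss beyond the scatter is expected for the step, a 2.9-fold higher number from compound 2 to compound 3 (0.46 log units; beyond the scatter) in this assay. Compound 3 is estimated at 1.3 ug/mL, with a range of 0.4 ug/mL to 4 ug/mL.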

Compound 3, half-maximal inhibitory concentration: 1 ug/mL
The estimate for compound 3 lay 1.3-fold (0.11 log units) above the measured number, within the range that was stated.
By their numbers in this assay, from the lowest: compound 2; then compound 3; then compound 1.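

Among the compounds shown here, on a double-bonded chain carbon bound to a double-bonded chain carbon, replacing the group with 3 double bonds outside aromatic rings by the group with 2 gives in this assay a 2.2-fold higher number from compound 2 to compound 3 (0.35 log units; beyond the scatter) as the first clean reading at this place. The change thus costs modestly, and the loss exceeds the scatter. Nothing available accounts for this shift. Open, on these data alone, is how this place would respond to a group with a different make-up, such as an amine or a carboxylic acid. A single step also leaves open whether the same change would cost as much on another core.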